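A few compounds are considered here, and "the series" means these few. Any claim that something is new, unique, unknown or untested is made for them only; others in the source may bear on it.

Measured in a functional assay on MCF7 cells (Homo sapiens) for inhibition, read by MTT assay, with a stated time of 48 h; on this read-out lower numbers stand for stronger inhibition and higher numbers for weaker inhibition:
compound 1 `COc1ccc(C(=O)C=CNc2cc(-c3ccccc3)nn2-c2ccccc2)cc1`: 1290 nM
compound 2 `O=C(C=CNc1cc(-c2ccccc2)nn1-c1ccccc1)c1ccc(Br)cc1`: 21700 nM
compound 3 `O=C(C=CNc1cc(-c2ccccc2)nn1-c1ccccc1)c1ccccc1`: 9650 nM

Compound 3 stands second highest of the three numbers, closest to compound 2. Compound 4 `Cc1ccc(C(=O)C=CNc2cc(-c3ccccc3)nn2-c2ccccc2)cc1` carries methyl in place of hydrogen on an aromatic carbon, para to a large group: methyl in place of hydrogen on an aromatic carbon. Two measured steps involve this same carbon: a 7.5-fold higher number from compound 1 to compound 3 (0.87 log units; beyond the scatter), and a 2.2-fold lower number from compound 2 to compound 3 (0.35 log units; beyond the scatter). Among the measured compounds shown here, they point in opposite directions, and no methyl compound has been measured. Methoxy is taken as the closer comparison, so a modest move to a lower number is expected in this assay, smaller than the methoxy step. The expected change is a 1.9-fold lower number from compound 3 to compound 4 (0.29 log units; within the scatter). For compound 4 the estimate is 5000 nM, with an expected range of 1800 nM to 13000 nM.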

Compound 4, half-maximal inhibitory concentration: 30200 nM
Compound 4: middle estimate off by 6.0-fold (0.78 log units), on the low side, outside the stated range (above it).
By their numbers in this assay, from the lowest: compound 1; then compound 3; then compounds 2 and 4 (each within the scatter of the next).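

In this assay, methyl on this aromatic carbon, para to a large group, does not follow methoxy (a 3.1-fold higher number from compound 3 to compound 4 (0.50 log units; beyond the scatter); a 23-fold higher number from compound 1 to compound 4 (1.37 log units; beyond the scatter)). Methyl and bromo are not separated here (a 1.4-fold higher number from compound 2 to compound 4 (0.14 log units; within the scatter)), so among these substituents only methoxy gives a lower number than hydrogen. No available evidence accounts for this split. Still open, on these data alone, is whether an amine or a hydroxyl group on this carbon would group with methoxy or with methyl and bromo. As far as these compounds go, whether a longer chain such as ethoxy keeps the methoxy result is also open.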